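The source may report more compounds than this note shows. Statements on the series, on what has been measured and on what is new or still open speak of the compounds shown alone.

In a functional assay on the whole organism with Mus musculus as the target, in the rotarod test (on this read-out higher numbers stand for an effect only at larger amounts of compound and lower numbers for an effect already at smaller amounts), compound 1 `O=C(/C=C1\CCc2ccccc21)NC1CC1` gives 235 mg/kg, while the difluorinated compound 2 `O=C(/C=C1\CCc2cc(F)cc(F)c21)NC1CC1` gives 81 mg/kg. Compound 2 therefore has the lower of the two numbers, and its gap to compound 1 lies beyond the scatter. Compound 3 `O=C(/C=C1\CCc2cc(F)ccc21)NC1CC1` differs from compound 2 by hydrogen in place of fluoro on an aromatic carbon, ortho to a fused ring and meta to a fluoro group. Compound 3 still carries a fluoro group, which compound 1 lacks, so its number is expected to fall between those of the two measured compounds. The estimated change, a 1.6-fold higher number from compound 2 to compound 3 (0.21 log units; within the scatter), is a modest rise in the number that is expected to stay within the scatter. For compound 3 the expected value in this assay is 130 mg/kg, with an estimated range of 75 mg/kg to 230 mg/kg.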

Compound 3, dose for half-maximal effect: 193 mg/kg
Beside the measured number, compound 3's estimate is 1.5-fold (0.17 log units) below it; the range from low to high includes it.
By their numbers in this assay, from the lowest: compound 2; then compounds 3 and 1 (each within the scatter of the next).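

For the compounds shown here, at the aromatic carbon ortho to a fused ring, the fluoro group matters in this assay: replacing it with hydrogen gives a 2.4-fold higher number from compound 2 to compound 3 (0.38 log units; beyond the scatter), a single-place step that the earlier compounds did not offer. The fluoro group kept in compound 3 does not match this on its own, as adding it gives only a 1.2-fold lower number from compound 1 to compound 3 (0.09 log units; within the scatter), which leaves compound 3 within the scatter of compound 1, while compound 2, with both fluoro groups, stands apart from compound 3. Nothing available explains why the two fluoro groups differ in this way.

The compounds shown leave open whether a single fluoro group on the carbon ortho to a fused ring would be enough without the second one. They also leave open whether a chloro or methoxy group on that carbon would behave as fluoro does.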